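A Second Methyl on the Shared Core

The compounds below may be only part of what the source reports. "The series", "measured", "known", "first", "only" and "open" are said of these compounds alone.

Compound 1 `Cc1ccc(C(=O)c2cc(Cl)ccc2Oc2ccnc(Nc3ccc(C#N)cc3)n2)cc1` is the most toxic of the three compounds measured in an ADME assay on MT4 cells (Homo sapiens) for cytotoxicity, read by MTT assay, with a stated time of 5 days (on this read-out higher numbers stand for lower toxicity in this test and lower numbers for higher toxicity in this test), where compound 1 gives 1710 nM. Compound 2 `Cc1ccccc1C(=O)c1cc(Cl)ccc1Oc1ccnc(Nc2ccc(C#N)cc2)n1` gives 28800 nM, and compound 3 `Cc1ccc(C(=O)c2cc(Cl)ccc2Oc2cc(C)nc(Nc3ccc(C#N)cc3)n2)cc1` gives 26600 nM. Both steps away from compound 1 lie beyond the scatter: a 17-fold higher number from compound 1 to compound 2 (1.23 log units; beyond the scatter) and a 16-fold higher number from compound 1 to compound 3 (1.19 log units; beyond the scatter). Compound 4 `Cc1ccc(C(=O)c2cc(Cl)ccc2Oc2nc(Nc3ccc(C#N)cc3)ncc2C)cc1` is not yet measured; its change from compound 1 is methyl in place of hydrogen on an aromatic carbon. Among the measured compounds shown here, the closest precedent is compound 3, also a methyl added to an aromatic carbon of the shared core, though at a different place. Because a 16-fold higher number from compound 1 to compound 3 (1.19 log units; beyond the scatter) was large, a similar rise in this assay is expected for compound 4, estimated as a 7.0-fold higher number from compound 1 to compound 4 (0.85 log units; beyond the scatter). The estimate for compound 4 is 12000 nM, with a range from 3000 nM to 40000 nM.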

Compound 4, half-maximal cytotoxic concentration: >= 830 nM
Compound 4: no number, only a limit; the forecaster's own chance of this, stated with the estimate: 10%; the middle value is on the limit's open side.
By their numbers in this assay, from the lowest: compound 1; then compounds 3 and 2 (each within the scatter of the next).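

Compound 4 gives only a limit in this assay, not a number, so no step from compound 1 to it can be read: the limit of >= 830 nM in this assay, at which 1 of the 4 values shown sits.

The compounds shown leave open how far the added methyl in compound 4 moves the number away from that of compound 1.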